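Swapping an aminophenyl for a dichlorophenyl on a chalcone-like scaffold

The source may report more compounds than this note shows. Statements on the series, on what has been measured and on what is new or still open speak of the compounds shown alone.

Compound 1 `COc1cc(-c2cc(/C=C/C(=O)c3ccc(N)cc3)[nH]n2)cc(OC)c1OC` is the weaker of the two compounds measured here: in a functional assay on NCI-H226 cells (Homo sapiens) for cytotoxicity, read by sulforhodamine B assay, with a stated time of 48 h, tested at 1 uM (a higher number here means a weaker effect of the compound at the concentration tested, a lower number a stronger effect), compound 1 gives 88%, while compound 2 `COc1ccc(-c2cc(/C=C/C(=O)c3ccc(OC)c(OC)c3)[nH]n2)cc1` gives 76%, a gap beyond the scatter. Compound 3 `COc1cc(-c2cc(/C=C/C(=O)c3ccc(Cl)c(Cl)c3)[nH]n2)cc(OC)c1OC` differs from compound 1 in one place: 3,4-dichlorophenyl in place of 4-aminophenyl on a carbonyl carbon. For the measured compounds named here, no measured pair shows what this change does, so the expectation rests only on the spread between compound 1 and compound 2. For compound 3 the effect is expected to strengthen modestly, a number 8 percentage points lower from compound 1 to compound 3 (within the scatter). Compound 3 is therefore estimated at 80%, within 55% to 100%.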

Compound 3, a percentage reported as activity, at one concentration (the size of the read-out at that concentration, not a potency): 96%
For compound 3 the middle estimate is 16 percentage points below the measured one; low and high end bracket the measured number.
By their numbers in this assay, from the lowest: compound 2; then compounds 1 and 3 (each within the scatter of the next).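

Putting 3,4-dichlorophenyl in place of 4-aminophenyl on a carbonyl carbon gives a number 8 percentage points higher from compound 1 to compound 3 (within the scatter) in this assay. For the compounds shown here, this is the first single-place comparison at this position, and it shows that the two groups cannot be told apart here, even though the hydrogen-bond donor and acceptor counted on 4-aminophenyl are absent from 3,4-dichlorophenyl. Nothing available explains this result. Open, as far as these compounds go, is whether a smaller group such as unsubstituted phenyl, or a phenyl carrying a carboxylic acid, would move the number beyond the scatter.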